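This account rests on a few compounds, and the source may have more. Where it says the series, first, only, none or still open, it means among the compounds named here.

Series notes. Compound 1 `O=C1/C(=C/c2ccccc2)CCC/C1=C\c1cccc([N+](=O)[O-])c1`, compound 2 `O=C1/C(=C/c2ccc(Cl)cc2)CCC/C1=C\c1ccccc1[N+](=O)[O-]` and compound 3 `O=C1/C(=C/c2ccc(Cl)cc2)CCC/C1=C\c1cccc([N+](=O)[O-])c1` have been measured in a functional assay on CCRF-CEM cells (Homo sapiens) for cytotoxicity, with a stated time of 72 h; a higher number here means a weaker inhibitor, a lower number a stronger inhibitor. Compound 1 gives 2290 nM; compound 2 gives 1750 nM; compound 3 gives 1750 nM. Compound 2 and compound 3 stand level at the digits shown, together the lowest of the three numbers. The two cores of compound 2 and compound 3 are built from the same atoms joined differently; that difference is not broken down here. From compound 3 to compound 1 the change is hydrogen in place of chloro on an aromatic carbon, and the step is a 1.3-fold higher number from compound 3 to compound 1 (0.12 log units; within the scatter). Going by these compounds, compound 4 `O=C1/C(=C/c2ccccc2)CCC/C1=C\c1ccccc1[N+](=O)[O-]` remains open in this assay; it arises from compound 2 by hydrogen in place of chloro on an aromatic carbon, the same change at the same place. For compound 4 a step of like size is expected, a 1.3-fold higher number from compound 2 to compound 4 (0.10 log units; within the scatter), resting on the step of a 1.3-fold higher number from compound 3 to compound 1 (0.12 log units; within the scatter) that stayed within the scatter. Compound 4 is accordingly estimated at 2200 nM in this assay, between 1100 nM and 4500 nM.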

Compound 4, half-maximal inhibitory concentration: 925 nM
The estimate for compound 4 lay 2.4-fold (0.38 log units) above the measured number, and the stated range ends above it.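

In this assay the new step is a 1.9-fold lower number from compound 2 to compound 4 (0.28 log units; within the scatter), so hydrogen in place of chloro stays within the scatter on this core as well. Set beside the earlier step, the two do not differ: the same change on two cores in this assay, a 1.3-fold higher number (0.12 log units; within the scatter) from compound 3 to compound 1 and a 1.9-fold lower number (0.28 log units; within the scatter) from compound 2 to compound 4, 2.5-fold (0.39 log units) apart, within the scatter of two such steps. The change 4-chlorophenyl to phenyl therefore carries between these two cores without a shift beyond the scatter, but two pairs give it no fixed direction or size and do not show that the core is without influence on it.

The compounds shown leave open whether a group other than chloro at that place, such as an amine or a carboxylic acid, would move the number beyond the scatter. They also leave open how the step behaves on any further core.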